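This account rests on a few compounds, and the source may have more. Where it says the series, first, only, none or still open, it means among the compounds named here.

Measured in a functional assay on HeLa cells (Homo sapiens) for antiproliferative activity, read by MTT assay, with a stated time of 48 h; on this read-out lower numbers stand for stronger inhibition of growth and higher numbers for weaker inhibition of growth:
- compound 1 `COC(=O)N1N=C(c2ccccc2)CC1c1cc(OC)c(OC)c(OC)c1`: 2180 nM
- compound 2 `CCCOC(=O)N1N=C(c2ccccc2)CC1c1cc(OC)c(OC)c(OC)c1`: > 10000 nM

Compound 2 reads > 10000 nM, which is a limit of the assay and not a number. Its true position is therefore unknown.

Compound 3 `COc1cc(C2CC(c3ccccc3)=NN2C(=O)OCc2ccccc2)cc(OC)c1OC` differs from compound 2 as follows: phenyl in place of ethyl on a saturated chain carbon bound to an oxygen next to a carbonyl group. In words, this is phenyl in place of ethyl on a saturated chain carbon bound to an oxygen next to a carbonyl group, so propoxycarbonyl becomes benzyloxycarbonyl.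

Among the measured compounds shown here, one measured step bears on this change, at the same place: an at least 4.5-fold higher number from compound 1 to compound 2 (0.66 log units; beyond the scatter). It runs toward weaker inhibition of growth, and a single step sets no trend. No gain beyond the scatter is expected in this assay, and a second limit reading is about as likely as a number.

The estimated step is a number no higher from compound 2 to compound 3 (the limit leaves the size open).

For compound 3 the expected value is 10000 nM, with an estimated range of 3000 nM to 30000 nM.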

Compound 3, concentration for 50% growth inhibition: > 10000 nM
Compound 3 gave a limit, no number; the forecaster's own chance of this, stated with the estimate: 55%; the middle value lies on the limit itself.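

In this assay compound 3 reads > 10000 nM, which is a limit of the assay and not a number. Benzyloxycarbonyl gives an at least 4.5-fold higher number from compound 1 to compound 3 (0.66 log units; beyond the scatter), so a second, ring-bearing group at this place moves the same way as propoxycarbonyl, and the loss is no longer tied to a single replacement. Compound 2 and compound 3 cannot be ordered against each other, and the step between them cannot be read: the limit of > 10000 nM in this assay, at which 2 of the 3 values shown sit.

Among the compounds shown here, compound 1 remains the only compound with a number, so how far the other two lie from it stays open. Also open, going by these compounds, is whether ethoxycarbonyl, or a chain ending in an amine or a carboxylic acid at this place, would give a number rather than another limit.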